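Nitro in Place of Fluoro on the Aryl Imine

This account rests on a few compounds, and the source may have more. Where it says the series, first, only, none or still open, it means among the compounds named here.

Compound 1, `C=C1CN/C(=N/c2ccccc2)S1`, in a functional assay on MCF7 cells (Homo sapiens) for antiproliferative activity, read by MTT assay, with a stated time of 72 h (a higher number here means a weaker inhibitor, a lower number a stronger inhibitor), gives only a limit, > 100000 nM.
Compound 2, `COc1ccc(/C=C2/CN(C)/C(=N/c3ccc(F)cc3)S2)cc1`, gives 8000 nM.
Compound 3, `COc1ccc(/C=C2\S/C(=N\c3ccc(F)cc3)N(C)C2=O)cc1`, gives 66500 nM.

Of the two numbers shown, compound 2 has the lower one; compound 3 lies above it by a gap beyond the usual scatter. Compound 4, `COc1ccc(/C=C2/CN(C)/C(=N/c3ccc([N+](=O)[O-])cc3)S2)cc1`, has not yet been measured. It differs from compound 2 by a single change: nitro in place of fluoro on an aromatic carbon. For the measured compounds named here, no measured pair here mirrors such a change, so the direction is not known from these data, and a step within the scatter, or little beyond it, is expected. Compound 4 is estimated at 6000 nM, within a range of 1500 nM to 25000 nM, which means an expected step of a 1.3-fold lower number from compound 2 to compound 4 (0.12 log units; within the scatter).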

Compound 4, half-maximal inhibitory concentration: 9800 nM
Estimate against measurement, compound 4: 1.6-fold (0.21 log units) below, and the stated range covers the measured number.
By their numbers in this assay, from the lowest: compounds 2 and 4 (each within the scatter of the next); then compound 3. At a limit, above all of these: compound 1.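

In this assay, for the compounds shown here, nitro in place of fluoro on an aromatic carbon para to a large group gives a 1.2-fold higher number from compound 2 to compound 4 (0.09 log units; within the scatter) and is the first step here that can be read at a single place. At this position, the read-out does not separate the two groups, even though nitro brings more heavy atoms and hydrogen-bond acceptors. Nothing in the data shown bears on the reason for this.

Going by these compounds, whether an amine or a carboxylic acid at this position would also stay within the scatter of compound 2 remains open. So does whether a longer chain there would be tolerated.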